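Aryl variation in a cinnamamide series at dopamine receptor

This account rests on a few compounds, and the source may have more. Where it says the series, first, only, none or still open, it means among the compounds named here.

Compound 1 `CCCN(CC[C@H]1CC[C@H](NC(=O)/C=C/c2ccc(F)cc2)CC1)[C@H]1CCc2nc(N)sc2C1` in an assay on brain for displacement of a labelled ligand from D(3) dopamine receptor (Rattus norvegicus) (a higher number here means a weaker inhibitor, a lower number a stronger inhibitor), compound 1 gives 1 nM.
Compound 2 `CCCN(CC[C@H]1CC[C@H](NC(=O)/C=C/c2ccc(Cl)cc2)CC1)[C@H]1CCc2nc(N)sc2C1` gives 2.5 nM.
Compound 3 `CCCN(CC[C@H]1CC[C@H](NC(=O)/C=C/c2ccccc2Cl)CC1)[C@H]1CCc2nc(N)sc2C1` gives 1.2 nM.

Compound 3 stands second highest of the three numbers: the steps of a 1.2-fold higher number from compound 1 to compound 3 (0.08 log units; within the scatter) and a 2.1-fold lower number from compound 2 to compound 3 (0.32 log units; beyond the scatter) place it within the scatter of one neighbour and beyond the scatter of the other. Compound 4 `CCCN(CC[C@H]1CC[C@H](NC(=O)/C=C/c2cccc(OC)c2)CC1)[C@H]1CCc2nc(N)sc2C1` differs from compound 3 in a single place: 3-methoxyphenyl in place of 2-chlorophenyl on a double-bonded chain carbon bound to a double-bonded chain carbon. No measured step swaps a halogen for a methoxy group, so the bearing of the shown steps is indirect. The aryl changes seen so far are small: a 2.5-fold higher number from compound 1 to compound 2 (0.40 log units; beyond the scatter) and a 2.1-fold lower number from compound 2 to compound 3 (0.32 log units; beyond the scatter) are modest, and a 1.2-fold higher number from compound 1 to compound 3 (0.08 log units; within the scatter) is within the scatter. Compound 4 is therefore expected to change this assay by little, in either direction, with the most likely outcome no step beyond the scatter, as the expected 1.7-fold higher number from compound 3 to compound 4 (0.22 log units; within the scatter) shows. Compound 4 is estimated at 2 nM, with a range from 0.6 nM to 7 nM.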

Compound 4, inhibition constant: 9.3 nM
The estimate for compound 4 lay 4.7-fold (0.67 log units) below the measured number; measured number above the stated range.
By their numbers in this assay, from the lowest: compounds 1 and 3 (each within the scatter of the next); then compound 2; then compound 4.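

In this assay, replacing a halogen-bearing ring with 3-methoxyphenyl raises the number in every comparison, with a 7.8-fold higher number from compound 3 to compound 4 (0.89 log units; beyond the scatter), a 3.7-fold higher number from compound 2 to compound 4 (0.57 log units; beyond the scatter) and a 9.3-fold higher number from compound 1 to compound 4 (0.97 log units; beyond the scatter), which makes compound 4 the weakest of the four. Each of these steps is larger than any step among compound 1, compound 2 and compound 3, so this position on the double-bonded chain carbon is less forgiving of this change than the halogen changes had suggested. Nothing available accounts for the loss.

Compound 4 changes both the substituent and where it sits on the ring, so the two contributions cannot be separated here. A 3-chlorophenyl or a 4-methoxyphenyl group would be needed to tell whether the methoxy group itself or its placement drives the higher number.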